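Ethoxy for methoxy carried onto a second core

The source may report more compounds than this note shows. Statements on the series, on what has been measured and on what is new or still open speak of the compounds shown alone.

Compound 1 `COc1nc(-c2cc3ccccc3o2)cc(-c2ccc(F)cc2)c1C#N` and compound 2 `CCOc1nc(-c2cc3ccccc3o2)cc(-c2ccc(F)cc2)c1C#N` differ in one place: methyl in place of hydrogen on a saturated chain carbon bound to an oxygen on an aromatic ring. In a functional assay on aorta (strain Wistar) for inhibition, with Thoracic aorta (Rattus norvegicus) as the target (on this read-out higher numbers stand for weaker inhibition and lower numbers for stronger inhibition), compound 1 gives 321000 nM, and compound 2 gives 396000 nM. The step of a 1.2-fold higher number from compound 1 to compound 2 (0.09 log units; within the scatter) is read as no change on this read-out.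

Compound 3 `COc1ccc(OC)c(-c2cc(-c3cc4ccccc4o3)nc(OC)c2C#N)c1` differs from compound 1 in more than one place; how the two cores differ is not broken down here. In this assay compound 3 gives 246000 nM, a number that sits with those of compound 1 and compound 2 and sets no order among the three.

Compound 4 `CCOc1nc(-c2cc3ccccc3o2)cc(-c2cc(OC)ccc2OC)c1C#N` is not yet measured. It stands to compound 3 as compound 2 stands to compound 1: methyl in place of hydrogen on a saturated chain carbon bound to an oxygen on an aromatic ring. The change occurs twice among these compounds, and the place is described in the same words both times, so it is the same change carried onto the core of compound 3. Among the measured compounds shown here, the only guide is the pair already measured, whose step stayed within the usual scatter. On that basis the step from compound 3 to compound 4 is expected to be a 1.2-fold higher number from compound 3 to compound 4 (0.07 log units; within the scatter), resting on the measured step of a 1.2-fold higher number from compound 1 to compound 2 (0.09 log units; within the scatter). Compound 4 is therefore expected to give 290000 nM in this assay, with a range from 150000 nM to 560000 nM allowing for scatter, a single measured pair being a thin base for the expectation.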

Compound 4, half-maximal inhibitory concentration: 327000 nM
Compound 4: the middle estimate sits 1.1-fold (0.05 log units) below what was measured, within the range that was stated.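

In this assay the methoxy to ethoxy change gives a 1.3-fold higher number from compound 3 to compound 4 (0.12 log units; within the scatter), so it again reads as no change on the second core, and the two cores agree: the same change on two cores in this assay, a 1.2-fold higher number (0.09 log units; within the scatter) from compound 1 to compound 2 and a 1.3-fold higher number (0.12 log units; within the scatter) from compound 3 to compound 4, 1.1-fold (0.03 log units) apart, within the scatter of two such steps. The other new step, 2,5-dimethoxyphenyl in place of 4-fluorophenyl on an aromatic carbon, gives a 1.2-fold lower number from compound 2 to compound 4 (0.08 log units; within the scatter), so the two ethoxy compounds are not told apart on this read-out either. This shows that the change carries from one core to the other as a step within the scatter, but it does not show that the change has no effect at all, as a small real effect could lie hidden on both cores, and two pairs say nothing about any third core.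

With only methoxy and ethoxy shown at this oxygen, it remains open whether a longer chain such as butoxy, or an amine in place of the whole alkoxy group, would move the number beyond the scatter. Every compound shown also carries the nitrile, so it is open whether a carboxylic acid in its place would leave the read-out where it sits.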